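Taking one methyl group off compound 3

A few compounds are considered here, and "the series" means these few. Any claim that something is new, unique, unknown or untested is made for them only; others in the source may bear on it.

In an ADME assay for pharmacokinetics, at pH 7.4 (on this read-out higher numbers stand for a longer-lived compound and lower numbers for a shorter-lived compound), compound 3 (`COc1c(C)cnc(C[S+]([O-])c2nc3cc(OC(F)F)ccc3[nH]2)c1C`) gives 15 h, the lowest of three measured numbers, against compound 1 (`COc1cnc(C[S+]([O-])c2nc3cc(OC(F)F)ccc3[nH]2)c(C)c1OC`) at 60 h and compound 2 (`COc1ccnc(C[S+]([O-])c2nc3cc(OC(F)F)ccc3[nH]2)c1`) at 51 h. Compound 4 (`COc1ccnc(C[S+]([O-])c2nc3cc(OC(F)F)ccc3[nH]2)c1C`) has hydrogen in place of methyl on an aromatic carbon of compound 3: hydrogen in place of methyl on an aromatic carbon. Going by the values given here, one measured step touches that carbon, a 4.0-fold lower number from compound 1 to compound 3 (0.60 log units; beyond the scatter), with methyl standing in place of methoxy. Among the compounds with values here, no measured step swaps methyl for hydrogen, so this guide is indirect. Compound 2 also carries hydrogen there and gives 51 h, but it differs elsewhere too. A modest rise is therefore expected, an estimated 2.0-fold higher number from compound 3 to compound 4 (0.30 log units; within the scatter). Compound 4 is estimated at 30 h, with an expected range of 15 h to 60 h.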

Compound 4, half-life: 3 h
The estimate for compound 4 lay 10-fold (1.00 log units) above the measured number; measured number below the stated range.
By their numbers in this assay, from the lowest: compound 4; then compound 3; then compounds 2 and 1 (each within the scatter of the next).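

This carbon has now carried three groups, and in this assay they fall in a clear order: hydrogen in place of methyl brings a 5.0-fold lower number from compound 3 to compound 4 (0.70 log units; beyond the scatter), and hydrogen in place of methoxy brings a 20-fold lower number from compound 1 to compound 4 (1.30 log units; beyond the scatter), so hydrogen ranks last, below methyl and methoxy. A different aromatic carbon also matters, as methyl in place of hydrogen there brings a 17-fold lower number from compound 2 to compound 4 (1.23 log units; beyond the scatter).

Nothing at hand explains these drops. From the compounds shown here alone, whether an ethoxy group or an amine on this carbon would outlast methoxy remains open.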